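Swapping Methoxy for Fluoro on a Shared Amide Core

The source may hold more compounds than are shown below. What is called first, only, known or untested is meant among the compounds shown, and "the series" means these compounds.

Compound 1 `COc1ccc(NC(=O)c2ccc3cccc(O)c3n2)cc1` is an amide whose core also appears in its neighbours. In an ADME assay on THP-1 cells (Homo sapiens) for cytotoxicity, read by WST assay, with a stated time of 24 h (on this read-out lower numbers stand for stronger inhibition and higher numbers for weaker inhibition), compound 1 gives > 30000 nM, which is a limit of the assay rather than a number. Compound 2 `Cc1ccc(NC(=O)c2ccc3cccc(O)c3n2)cc1` carries methyl in place of methoxy on an aromatic carbon. In this assay compound 2 gives > 30000 nM, again a limit. Compound 3 `O=C(Nc1cccc(F)c1)c1ccc2cccc(O)c2n1` carries 3-fluorophenyl in place of 4-methylphenyl on an amide-type nitrogen. In this assay compound 3 gives > 30000 nM, also a limit. The change from compound 1 to compound 4 `O=C(Nc1ccc(F)cc1)c1ccc2cccc(O)c2n1` is fluoro in place of methoxy on an aromatic carbon. Among the compounds with values here, two measured steps bear on it: a step that the two limits leave unreadable from compound 1 to compound 2 and a step that the two limits leave unreadable from compound 2 to compound 3, both hidden because of the limit of > 30000 nM in this assay, at which 3 of the 3 values shown sit. Within the data shown here, with every value sitting at that limit, no step of readable size appears in this assay, in either direction. Compound 4 is therefore expected to give 50000 nM, within 20000 nM to 200000 nM, and most likely to be reported again as a limit. For compound 4 the step that the limit leaves unreadable from compound 1 to compound 4 is expected to be none beyond the scatter.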

Compound 4, half-maximal inhibitory concentration: > 30000 nM
Compound 4: only a limit was reported; the forecaster's own chance of this, stated with the estimate: 85%; the middle value lies beyond the limit too.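

No step can be read between compound 1, compound 2, compound 3 and compound 4 in this assay, because every comparison ends at the same limit: the limit of > 30000 nM in this assay, at which 4 of the 4 values shown sit. The compounds shown leave open whether these changes to the shared core alter cytotoxicity, and what true value each compound has.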